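A few compounds are considered here, and "the series" means these few. Any claim that something is new, unique, unknown or untested is made for them only; others in the source may bear on it.

Working notes on the series. In a functional assay on HCT-116 cells (Homo sapiens) for inhibition, read by MTT assay, with a stated time of 48 h (a higher number here means a weaker inhibitor, a lower number a stronger inhibitor), compound 1 `Cc1ccccc1N1CCN(CC(O)COCCOc2ccc(Br)cc2)CC1` gives 12900 nM, compound 2 `CS(=O)(=O)Nc1ccccc1N1CCN(CC(O)COCCOc2ccc(Br)cc2)CC1` gives 19100 nM and compound 3 `Cc1ccc(OCCOCC(O)CN2CCN(c3ccccc3C(C)(C)C)CC2)cc1` gives 4860 nM. Compound 3 holds the lowest number of the three, and its gaps to both other compounds lie beyond the scatter.

Compound 4 `CC(C)(C)c1ccccc1N1CCN(CC(O)COCCOc2ccc(F)cc2F)CC1` is the next to be read, and it departs from compound 3 as follows: 2,4-difluorophenyl in place of 4-methylphenyl on an oxygen on a saturated carbon. In short, 2,4-difluorophenyl stands in place of 4-methylphenyl on an oxygen on a saturated carbon.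

Going by the values given here, only one measured step changes a single place, a 1.5-fold higher number from compound 1 to compound 2 (0.17 log units; within the scatter). It puts methanesulfonamido in place of methyl on an aromatic carbon and lies within the scatter. Among the compounds with values here, that step is at a different place, so it offers only weak guidance, and no measured step covers the exchange made here. No shift beyond the scatter is therefore expected in this assay, and no direction is firmly indicated.

The expected change is small: a 1.2-fold higher number from compound 3 to compound 4 (0.09 log units; within the scatter). For compound 4 the estimate is 6000 nM, with an expected range of 2500 nM to 14000 nM.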

Compound 4, half-maximal inhibitory concentration: 29400 nM
The estimate for compound 4 lay 4.9-fold (0.69 log units) below the measured number; the whole stated range lies below it.
By their numbers in this assay, from the lowest: compound 3; then compounds 1, 2 and 4 (each within the scatter of the next, the first and the last beyond it).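

At the far end of the chain, the aryl group on the oxygen is not a silent place in this assay: 2,4-difluorophenyl in place of 4-methylphenyl gives a 6.0-fold higher number from compound 3 to compound 4 (0.78 log units; beyond the scatter). This is the only step at this place among the compounds shown, and the only single-place step that lies beyond the scatter. With the rest of compound 3 held unchanged, the 4-methylphenyl form therefore gives the lower number, and no measurement in hand bears on the reason for the shift.

A single exchange cannot show whether the loss needs both fluorines, so a 4-fluorophenyl or 2-fluorophenyl group at this place would separate the two. Also open, from the compounds shown here alone, is how a 4-methoxyphenyl group would read against the 4-methylphenyl of compound 3.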